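The source may hold more compounds than are shown below. What is called first, only, known or untested is meant among the compounds shown, and "the series" means these compounds.

In a functional assay on KB cells (Homo sapiens) for antiproliferative activity, read by colorimetric assay and MTT assay (a higher number here means a weaker inhibitor, a lower number a stronger inhibitor), compound 1 (`O=S(=O)(Nc1cccc2cc[nH]c12)c1ccc(Cl)cc1`) gives 6 ug/mL, compound 2 (`O=S(=O)(Nc1ccc(Cl)c2cc[nH]c12)c1ccc(Cl)cc1`) gives 9.7 ug/mL and compound 3 (`O=[N+]([O-])c1ccc(S(=O)(=O)Nc2cccc3c(Cl)c[nH]c23)cc1`) gives 14 ug/mL. Compound 2 thus lies within the scatter of both other compounds. Compound 4 (`O=[N+]([O-])c1ccc(S(=O)(=O)Nc2ccc(Cl)c3cc[nH]c23)cc1`) has nitro in place of chloro on an aromatic carbon, para to a large group: nitro in place of chloro on an aromatic carbon. For the measured compounds named here, no measured step makes this exchange. The only one, a 1.6-fold higher number from compound 1 to compound 2 (0.21 log units; within the scatter), places chloro on a different carbon and bears on it only indirectly. Compound 3 also carries nitro, at 14 ug/mL, though its chloro sits elsewhere. No change beyond the scatter is therefore expected in this assay. The expected step is a 1.1-fold higher number from compound 2 to compound 4 (0.05 log units; within the scatter). For compound 4 the estimated value is 11 ug/mL, with an expected range from 5 ug/mL to 24 ug/mL.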

Compound 4, half-maximal inhibitory concentration: 9.1 ug/mL
For compound 4 the middle estimate is 1.2-fold (0.08 log units) above the measured one, and the stated range covers the measured number.
By their numbers in this assay, from the lowest: compounds 1, 4, 2 and 3 (each within the scatter of the next, the first and the last beyond it).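

In this assay, for the compounds shown here, the exchange gives a 1.1-fold lower number from compound 2 to compound 4 (0.03 log units; within the scatter), the first direct reading of nitro against chloro on this aromatic carbon, para to a large group, and this assay does not separate the two groups here. Nitro enters with hydrogen-bond acceptors that chloro lacks, yet the number stays within the scatter. Nothing measured here accounts for this result. The compounds shown leave open whether an amine or a carboxylic acid on this carbon would also stay within the scatter, and whether a longer chain would.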